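Methyl removal on the dimethylphenyl ring of compound 3

A few compounds are considered here, and "the series" means these few. Any claim that something is new, unique, unknown or untested is made for them only; others in the source may bear on it.

Three compounds of the shared core have numbers in a functional assay on B16-F0 cells (Mus musculus) for inhibition, read by CCK-8 assay, with a stated time of 48 h; a lower number here means a stronger inhibitor, a higher number a weaker inhibitor. Compound 1 `COc1cc(-c2cc3nccc(-c4c[nH]c5ccccc45)n3n2)cc(OC)c1OC` sits at the limit of the assay, > 10000 nM, which is a limit and not a number (the limit of > 10000 nM in this assay, at which 1 of the 3 values shown sits). Compound 2 `Cn1ccc2cc(-c3cc4nccc(-c5ccc(F)cc5)n4n3)ccc21` gives 4780 nM. Compound 3 `COc1cc(-c2ccnc3cc(-c4ccc(C)c(C)c4)nn23)cc(OC)c1OC` gives 391 nM, the lowest of the two numbers; the gap to compound 2 lies beyond the usual scatter.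

Compound 4 `COc1cc(-c2ccnc3cc(-c4cccc(C)c4)nn23)cc(OC)c1OC` is not yet measured. It differs from compound 3 by hydrogen in place of methyl on an aromatic carbon; cut one bond further out, this reads 3,4-dimethylphenyl to 3-methylphenyl. Going by the values given here, no pair of measured compounds differs in one place, so the size of such a step is not known from these data. The change is small and leaves the rest of compound 3 intact; the expectation is a modest move towards weaker inhibition, possibly no larger than the scatter. The step from compound 3 to compound 4 is estimated at a 1.8-fold higher number from compound 3 to compound 4 (0.25 log units; within the scatter). For compound 4 a value of 700 nM is estimated, with a range of 250 nM to 2500 nM in this assay.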

Compound 4, half-maximal inhibitory concentration: 2220 nM
Compound 4: middle estimate off by 3.2-fold (0.50 log units), on the low side; low and high end bracket the measured number.
By their numbers in this assay, from the lowest: compound 3; then compound 4; then compound 2. At a limit, above all of these: compound 1.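

Going by these compounds alone, the first single-place comparison gives, in this assay, a 5.7-fold higher number from compound 3 to compound 4 (0.75 log units; beyond the scatter). The methyl that leaves, ortho to a methyl group and para to a large group, therefore matters in this assay: the loss of one heavy atom moves the number beyond the scatter while the rest of compound 3 stays intact. No measurement shown here accounts for the size of this step.

As far as these compounds go, whether this position favours methyl specifically or would accept other groups remains open; a methoxy group, a chlorine atom or an amine on the same aromatic carbon would help to settle this. Also open, from the compounds shown here alone, is what the methyl retained in compound 4 contributes, which a plain phenyl ring in its place would show.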